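The source may hold more compounds than are shown below. What is called first, only, known or untested is meant among the compounds shown, and "the series" means these compounds.

The series shares the core shown by compound 1 `O=[N+]([O-])c1ccc(CSc2nc(NC3CC3)nc3c2ncn3[C@@H]2O[C@H](CO)[C@@H](O)[C@H]2O)cc1` and varies the group on a nitrogen on an aromatic ring. In an assay on K562 cells for displacement of a labelled ligand from Equilibrative nucleoside transporter 1 (Homo sapiens), read by flow cytometry, with a stated time of 45 min (a lower number here means a stronger inhibitor, a higher number a weaker inhibitor), compound 1 gives 25 nM. Compound 2 `O=[N+]([O-])c1ccc(CSc2nc(NC3CCC3)nc3c2ncn3[C@@H]2O[C@H](CO)[C@@H](O)[C@H]2O)cc1` carries cyclobutyl in place of cyclopropyl at that nitrogen; in this assay compound 2 gives 33 nM. The step of a 1.3-fold higher number from compound 1 to compound 2 (0.12 log units; within the scatter) is the only one measured so far, and it leaves compound 2 and compound 1 within the scatter of each other, so the two numbers stand together rather than apart.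

Compound 3 `O=[N+]([O-])c1ccc(CSc2nc(NC3CCCCC3)nc3c2ncn3[C@@H]2O[C@H](CO)[C@@H](O)[C@H]2O)cc1` is not yet measured. It differs from compound 2 by cyclohexyl in place of cyclobutyl on a nitrogen on an aromatic ring. Within the data shown here, the one step that bears on this, a 1.3-fold higher number from compound 1 to compound 2 (0.12 log units; within the scatter), widened the same ring without moving the number beyond the scatter; the present change widens it further, from cyclobutyl to cyclohexyl. Among the measured compounds shown here, no step of that size has been measured, so the expectation rests on extending the single small step: a modest upward move, a 1.2-fold higher number from compound 2 to compound 3 (0.08 log units; within the scatter), is expected, though a step within the scatter is about as plausible. Compound 3 is therefore estimated at 40 nM in this assay, with a range from 15 nM to 110 nM.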

Compound 3, inhibition constant: 400 nM
Estimate against measurement, compound 3: 10-fold (1.00 log units) below, outside the stated range (above it).
By their numbers in this assay, from the lowest: compounds 1 and 2 (each within the scatter of the next); then compound 3.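

In this assay the group on a nitrogen on an aromatic ring proves sensitive to ring size: cyclopropyl and cyclobutyl stand together, yet cyclohexyl brings a 12-fold higher number from compound 2 to compound 3 (1.08 log units; beyond the scatter) and also a 16-fold higher number from compound 1 to compound 3 (1.20 log units; beyond the scatter) at the same place. The flat stretch seen with the two smallest rings therefore does not carry through to the six-membered ring, so among these three compounds the position accepts a change of ring only over part of the range, and the step from cyclobutylamino to cyclohexylamino is far larger than the one before it. Nothing at hand offers an explanation for this jump.

The compounds shown leave open where between the four-membered and six-membered rings the number starts to climb, and cyclopentyl would settle whether the rise is gradual or abrupt. Also open, from the compounds shown here alone, is whether the rise belongs to the six-membered ring as such or to its size in carbon alone, a question that tetrahydropyranyl, with a ring oxygen, or an open chain such as n-butyl would address.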